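Compound 3 to compound 4: methoxy to trifluoromethoxy

The source may report more compounds than this note shows. Statements on the series, on what has been measured and on what is new or still open speak of the compounds shown alone.

In an ADME assay on a cell-free system (plasma, Homo sapiens) for protein binding, compound 3 `CNc1nccc(N2CC[C@H](NC(=O)Nc3ccc(OC)cc3)C2)n1` reads 80% and has the highest unbound fraction of the three measured compounds. Compound 2 `CNc1nccc(N2CC[C@H](NC(=O)Nc3cccc(C#N)c3)C2)n1` stands at 94.4% and compound 1 `CNc1nccc(N2CC[C@H](NC(=O)Nc3cc(OC)cc(OC)c3)C2)n1` at 98.1%, and both of them have a smaller unbound fraction than compound 3.

Compound 4 `CNc1nccc(N2CC[C@H](NC(=O)Nc3ccc(OC(F)(F)F)cc3)C2)n1` carries a single change from compound 3, with trifluoromethyl in place of methyl on an oxygen on an aromatic ring as its count: trifluoromethyl in place of methyl on an oxygen on an aromatic ring.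

Among the measured compounds shown here, no measured step touches this group. For the measured compounds named here, the one single-change step is a 3.6-fold higher unbound fraction from compound 2 to compound 3 (0.55 log units; beyond the scatter) and lies beyond the scatter, but it is a different replacement, so it offers a size and no direction. The direction rests only on compound 3 at 80% having the highest unbound fraction so far, which leaves a lower unbound fraction as the more likely move in this assay for this change. The expected size is a 3.3-fold lower unbound fraction from compound 3 to compound 4 (0.52 log units; beyond the scatter) as an estimate, similar to the measured step. For compound 4 the estimated value is 94% with 88% to 97.5% as the expected range.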

Compound 4, plasma protein binding: 97.7%
Compound 4: middle estimate off by 2.6-fold (0.42 log units) (unbound fraction), on the high side; measured number above the stated range.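

In this assay, trifluoromethyl in place of methyl on an oxygen on an aromatic ring gives an 8.7-fold lower unbound fraction from compound 3 to compound 4 (0.94 log units; beyond the scatter). Within this pair, a change confined to the group on that oxygen is enough to move the read-out beyond the scatter, whereas the earlier step, a 3.6-fold higher unbound fraction from compound 2 to compound 3 (0.55 log units; beyond the scatter), exchanged one substituted phenyl for another. Nothing shown accounts for the size or direction of this shift.

On these data alone, it remains open whether difluoromethyl on the same oxygen would give a value nearer compound 3 or compound 4, and whether an ethyl group or a chain ending in an amine or a carboxylic acid would keep the unbound fraction near that of compound 3. Whether the same replacement would shift the methoxy groups of compound 1 in the same direction also stays unresolved.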